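A Single Stereocentre Inverted in a Peroxide Acid Series

The source may report more compounds than this note shows. Statements on the series, on what has been measured and on what is new or still open speak of the compounds shown alone.

Compound 1 `C=C1CCC[C@H]2[C@](C)(CC[C@]3(C)CC[C@@H]([C@@H](C)C(=O)O)OO3)[C@@H](C)CC[C@]12C` is the reference point of this account. In a functional assay on OVCAR-5 cells (Homo sapiens) for inhibition (a lower number here means a stronger inhibitor of growth, a higher number a weaker inhibitor of growth), compound 1 gives 2720 nM. For the measured compounds named here, compound 2 `C=C1CCCC(C)(C)C1CC[C@@]1(C)CC[C@H]([C@@H](C)C(=O)O)OO1` is the only other compound with a reading, and for compound 2 this assay reports only a limit, > 12500 nM, which is a boundary of the measurement and not a number. Going by the values given here, compound 1 thus holds the only true number in this assay, the other reading sitting at the limit of > 12500 nM in this assay, at which 1 of the 2 values shown sits.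

The step of interest leads to compound 3 `C=C1CCC[C@H]2[C@](C)(CC[C@]3(C)CC[C@H]([C@@H](C)C(=O)O)OO3)[C@@H](C)CC[C@]12C`, which differs from compound 1 in this way: the two compounds have the same atoms and bonds and differ only in configuration as drawn: 1 of 7 stereo elements differ; a stereocentre at a saturated ring carbon is drawn S in compound 1 and R in compound 3. Among the compounds with values here, no pair of measured compounds differing in a single place is available, so the size of such a step in this assay is not anchored by any measurement here. A change of configuration at one saturated ring carbon is expected to move the reading of this assay by a modest amount, most likely toward weaker inhibition, though a shift within the scatter cannot be excluded.

Compound 3 is therefore estimated to give 4500 nM in this assay, within a range from 1500 nM to 12500 nM. This estimate for compound 3 means a step of a 1.7-fold higher number from compound 1 to compound 3 (0.22 log units; within the scatter).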

Compound 3, concentration for 50% growth inhibition: 1740 nM
Compound 3: middle estimate off by 2.6-fold (0.41 log units), on the high side; the measured number falls inside the stated range.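

Inverting the saturated ring carbon from S to R gives, in this assay, a 1.6-fold lower number from compound 1 to compound 3 (0.19 log units; within the scatter), a step that lies within the scatter. This is the only step shown between compounds that differ in one place, and it shows that the two drawn configurations at this carbon give readings that cannot be told apart, so neither form can be ranked above the other in this assay. No group enters or leaves in this step, so the comparison concerns configuration at this one carbon alone: the fact that compounds 1 and 3 differ only in the configuration as drawn

Compound 2 stays at > 12500 nM, which is a limit and not a number, so no step can be read from it. The compounds shown leave open whether a methyl ester or a primary amide in place of the carboxylic acid would change the reading in either configuration, and whether inverting any of the other stereocentres would give a step beyond the scatter.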